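A Fluorobenzyl Swap on an Inactive Ester

This account rests on a few compounds, and the source may have more. Where it says the series, first, only, none or still open, it means among the compounds named here.

Measured in a functional assay on SK-BR-3 cells (Homo sapiens) for antiproliferative activity, read by MTT assay, with a stated time of 72 h (a lower number here means a stronger inhibitor, a higher number a weaker inhibitor), all three values are limits:
- Compound 1 `C/C=C1/[C@H](O[C@@H]2O[C@H](CO)[C@@H](O)[C@H](O)[C@H]2O)OC=C(C(=O)OC)[C@H]1CC(=O)OCCc1ccc2c(c1)OCCO2`: > 20000 nM
- Compound 2 `C#CCOC(=O)C[C@@H]1C(C(=O)OC)=CO[C@@H](O[C@@H]2O[C@H](CO)[C@@H](O)[C@H](O)[C@H]2O)/C1=C/C`: > 15000 nM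
- Compound 3 `C/C=C1/[C@H](O[C@@H]2O[C@H](COC(C)=O)[C@@H](OC(C)=O)[C@H](OC(C)=O)[C@H]2OC(C)=O)OC=C(C(=O)OC)[C@H]1CC(=O)OC`: > 15000 nM

Compound 2 gives > 15000 nM, which is a limit and not a number. For the measured compounds named here, this is the limit of > 15000 nM in this assay, at which 2 of the 3 values shown sit, so no compound here has a measured number to compare.

Compound 4 `C/C=C1/[C@H](O[C@@H]2O[C@H](CO)[C@@H](O)[C@H](O)[C@H]2O)OC=C(C(=O)OC)[C@H]1CC(=O)OCCc1ccc(F)cc1` changes compound 2 as follows: 4-fluorobenzyl in place of ethynyl on a saturated chain carbon bound to an oxygen next to a carbonyl group. Read one bond further out, propargyl gives way to 2-(4-fluorophenyl)ethyl.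

Going by the values given here, the only measured step that bears on this is a step that the two limits leave unreadable from compound 1 to compound 2. It is a swap at the same place, and its size cannot be read. Compound 1 carries a larger group there, (2,3-dihydro-1,4-benzodioxin-6-yl)methyl, and its > 20000 nM is also a limit. A large group at this place has therefore not yet given a measurable value, so no step beyond the scatter is expected in this assay, in either direction.

The expected change is a step that the limit leaves unreadable from compound 2 to compound 4. For compound 4 the estimate is 20000 nM, with an expected range of 10000 nM to 50000 nM.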

Compound 4, half-maximal inhibitory concentration: > 20000 nM
Compound 4: only a limit was reported; the forecaster's own chance of this, stated with the estimate: 85%; the middle value sits exactly at the limit.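

Compound 4 returned only a limit, and so did compound 1 and compound 2, so the steps from either of them to compound 4 cannot be read. The compounds shown leave open whether any group at this place on the shared core gives a measured number in this assay.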